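A few compounds are considered here, and "the series" means these few. Any claim that something is new, unique, unknown or untested is made for them only; others in the source may bear on it.

Of the compounds shown here, three sharing one core have been measured in an assay on membranes from liver for displacement of a labelled ligand from Sigma non-opioid intracellular receptor 1 (Rattus norvegicus); on this read-out lower numbers stand for stronger inhibition and higher numbers for weaker inhibition. Compound 1 `O=c1oc2ccccc2n1CC1CCN(Cc2ccccc2)CC1` gives 3.6 nM. Compound 2 `O=c1oc2ccccc2n1CC1CCN(Cc2ccccc2Cl)CC1` gives 61 nM. Compound 3 `O=c1oc2ccccc2n1CC1CCN(Cc2ccc(Cl)cc2Cl)CC1` gives 258 nM, the highest of the three numbers, reached by a step of a 4.2-fold higher number from compound 2 to compound 3 (0.63 log units; beyond the scatter) and, from the smallest number, by a 72-fold higher number from compound 1 to compound 3 (1.86 log units; beyond the scatter). Compound 4 `Cc1ccc(CN2CCC(Cn3c(=O)oc4ccccc43)CC2)c(C)c1` has not yet been measured. It differs from compound 3 in one place: 2,4-dimethylphenyl in place of 2,4-dichlorophenyl on a saturated chain carbon bound to an amine nitrogen in a ring. The measured steps all concern chloro entering in place of hydrogen on the phenyl: a 17-fold higher number from compound 1 to compound 2 (1.23 log units; beyond the scatter) and a 4.2-fold higher number from compound 2 to compound 3 (0.63 log units; beyond the scatter), which together amount to a 72-fold higher number from compound 1 to compound 3 (1.86 log units; beyond the scatter). None of them exchanges chloro for methyl, so they show only that a 2,4-dichlorophenyl gives a far higher number than a plain phenyl; what a 2,4-dimethylphenyl does in this assay is not shown. The change is therefore expected to shift the number only slightly, a 1.7-fold lower number from compound 3 to compound 4 (0.24 log units; within the scatter), with wide uncertainty. Compound 4 is estimated at 150 nM, between 40 nM and 600 nM.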

Compound 4, inhibition constant: 30 nM
Estimate against measurement, compound 4: 5.0-fold (0.70 log units) above, and the stated range ends above it.
By their numbers in this assay, from the lowest: compound 1; then compound 4; then compound 2; then compound 3.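

In this assay, within the data shown here, 2,4-dimethylphenyl in place of 2,4-dichlorophenyl gives an 8.6-fold lower number from compound 3 to compound 4 (0.93 log units; beyond the scatter) and so this position tells the two groups apart, which no earlier step could show. The dimethyl group also compares well with 2-chlorophenyl, giving a 2.0-fold lower number from compound 2 to compound 4 (0.31 log units; beyond the scatter) while still falling short of the plain phenyl with an 8.3-fold higher number from compound 1 to compound 4 (0.92 log units; beyond the scatter) so that all three substituted phenyls give higher numbers than the unsubstituted one, though by different amounts. Nothing available explains why methyl and chloro differ here.

Among these compounds, whether a single methyl on the phenyl would give a lower number than the single chloro of compound 2 remains open, as does the effect of fluoro or methoxy at this position. Also open, going by these compounds, is what an amine or a carboxylic acid on the phenyl would do, or a longer chain in place of the saturated chain carbon.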